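The source may hold more compounds than are shown below. What is called first, only, known or untested is meant among the compounds shown, and "the series" means these compounds.

In a functional assay on A549 cells (Homo sapiens) for antiproliferative activity, read by MTT assay, with a stated time of 48 h (on this read-out lower numbers stand for stronger inhibition and higher numbers for weaker inhibition), compound 1 `COc1ccc(/C=C/C=C\c2cc(OC)c(OC)c(OC)c2)cc1O` gives 118 nM, compound 2 `CCOc1cc(-c2ccc3cc[nH]c3c2)cn2c(-c3cc(OC)c(OC)c(OC)c3)nnc12` gives 626 nM and compound 3 `CCOc1cc(-c2ccc3[nH]ccc3c2)cn2c(-c3cc(OC)c(OC)c(OC)c3)nnc12` gives 589 nM. Compound 3 thus stands within the scatter of compound 2, while compound 1 has a number beyond the scatter on the lower side. Compound 4 `COc1cc(-c2nnc3c(OC)cc(-c4ccc5[nH]ccc5c4)cn23)cc(OC)c1OC` differs from compound 3 in one place: hydrogen in place of methyl on a saturated chain carbon bound to an oxygen on an aromatic ring, which reads as ethoxy to methoxy. Among the compounds with values here, the only measured step, a 1.1-fold lower number from compound 2 to compound 3 (0.03 log units; within the scatter), concerns the indolyl group and not this chain, so the data hold no direct precedent. No step beyond the scatter is expected in this assay. The expected step, a 1.3-fold lower number from compound 3 to compound 4 (0.12 log units; within the scatter), is an estimate with no firm direction. Compound 4 is estimated at 450 nM, with an expected range of 150 nM to 1300 nM.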

Compound 4, half-maximal inhibitory concentration: 167 nM
Compound 4: the middle estimate sits 2.7-fold (0.43 log units) above what was measured; low and high end bracket the measured number.
By their numbers in this assay, from the lowest: compounds 1 and 4 (each within the scatter of the next); then compounds 3 and 2 (each within the scatter of the next).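

In this assay, within the data shown here, the group on the oxygen is the first place where a single change moves the number beyond the scatter: ethoxy to methoxy gives a 3.5-fold lower number from compound 3 to compound 4 (0.55 log units; beyond the scatter), whereas the indolyl change gave only a 1.1-fold lower number from compound 2 to compound 3 (0.03 log units; within the scatter). This position therefore responds to the loss of one methyl, with methoxy on the lower side of ethoxy. No measurement shown explains this step.

From the compounds shown here alone, whether a longer chain such as propoxy, or an amine, would fit this place remains open. Also open, going by these compounds, is whether methoxy gives a similar step alongside the 1H-indol-6-yl group of compound 2.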